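Chloro in Place of Methyl: Compound 2 to Compound 3

The source may hold more compounds than are shown below. What is called first, only, known or untested is meant among the compounds shown, and "the series" means these compounds.

Compound 1 `Cn1c(-c2ccccc2)nc2c(NC3CCCCC3)ncnc21` and compound 2 `Cc1ccc(-c2nc3c(NC4CCCC4)ncnc3n2C)cc1` share one core and differ at two places. In an assay on CHO cells for displacement of a labelled ligand from adenosine receptor A1 (Homo sapiens), read by scintillation counting, with a stated time of 3 h (on this read-out higher numbers stand for weaker inhibition and lower numbers for stronger inhibition), compound 1 gives 5.7 nM, and compound 2 gives 8 nM; these two numbers lie within the usual scatter of each other, so no order between them can be read. Compound 3 `Cn1c(-c2ccc(Cl)cc2)nc2c(NC3CCCC3)ncnc21` is not yet measured. It differs from compound 2 by chloro in place of methyl on an aromatic carbon. Going by the values given here, no measured pair shows this change, so the expected step is small, not beyond the scatter in either direction: the step from no change at the digits printed from compound 2 to compound 3 (within the scatter) is an estimate. Compound 3 is expected to give 8 nM in this assay, within 3 nM to 20 nM.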

Compound 3, inhibition constant: 18 nM
The estimate for compound 3 lay 2.3-fold (0.35 log units) below the measured number; the range from low to high includes it.
By their numbers in this assay, from the lowest: compounds 1 and 2 (each within the scatter of the next); then compound 3.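

In this assay, going from 4-methylphenyl to 4-chlorophenyl gives a 2.3-fold higher number from compound 2 to compound 3 (0.35 log units; beyond the scatter), a modest weakening of inhibition. This shows that the aromatic carbon para to a large group responds to the exchange of a single heavy atom, which compounds 1 and 2, differing at two places, could not show. Nothing available here explains the direction of this step. From the compounds shown here alone, whether an amine, a methoxy group or a carboxylic acid at this position would strengthen or weaken inhibition remains open.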